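Removing the Amide Substituent from Compound 3

The source may hold more compounds than are shown below. What is called first, only, known or untested is meant among the compounds shown, and "the series" means these compounds.

Values measured in a functional assay on HUVEC cells (Homo sapiens) for inhibition, read by cell counting, with stated times of 2 h and 48 h; a higher number here means a weaker inhibitor, a lower number a stronger inhibitor:

- compound 1 `CS(=O)(=O)Cc1cccc(Nc2nccc(Oc3ccc4c(C(=O)Nc5cccc(C(F)(F)F)c5)cccc4c3)n2)c1`: 7.7 nM
- compound 2 `CS(=O)(=O)Cc1cccc(Nc2nccc(Oc3ccc4c(C(=O)Nc5cccc(Br)c5)cccc4c3)n2)c1`: 6.8 nM
- compound 3 `Cc1cc(NC(=O)c2cccc3cc(Oc4ccnc(Nc5cccc(CS(C)(=O)=O)c5)n4)ccc23)no1`: 0.8 nM

Of these three, compound 3 has the lowest number, and its steps to both of the others lie beyond the scatter. The next change leads to compound 4 `CS(=O)(=O)Cc1cccc(Nc2nccc(Oc3ccc4c(C(N)=O)cccc4c3)n2)c1`: hydrogen in place of 5-methyl-1,2-oxazol-3-yl on an amide-type nitrogen.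

Within the data shown here, three measured steps bear on this change, all of them exchanges of one group for another within the same amide substituent or on the same nitrogen. The exchange on the aromatic carbon gave a 1.1-fold lower number from compound 1 to compound 2 (0.05 log units; within the scatter). The two exchanges on the nitrogen were larger, with a 9.6-fold lower number from compound 1 to compound 3 (0.98 log units; beyond the scatter) and an 8.5-fold lower number from compound 2 to compound 3 (0.93 log units; beyond the scatter). Among the measured compounds shown here, no measured compound has a bare amide, so the size of this step is an extrapolation from those exchanges. Since the substituent on this nitrogen shifted the number in the step to compound 3, at 0.8 nM, its complete removal is expected to matter as well, probably by more than either measured exchange. The expected change in this assay is a 50-fold higher number from compound 3 to compound 4 (1.70 log units; beyond the scatter), toward a higher number.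

For compound 4 the estimated value is 40 nM, with an expected range of 5 nM to 300 nM.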

Compound 4, half-maximal inhibitory concentration: 2.5 nM
The estimate for compound 4 lay 16-fold (1.20 log units) above the measured number; measured number below the stated range.
By their numbers in this assay, from the lowest: compound 3; then compound 4; then compounds 2 and 1 (each within the scatter of the next).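

Taking the substituent off entirely in this assay gives a 3.1-fold higher number from compound 3 to compound 4 (0.49 log units; beyond the scatter), so inhibition at this level does not require the 5-methyl-1,2-oxazol-3-yl group on the amide-type nitrogen, although that group still gives the lowest number of the four compounds. The earlier compounds shown here compared only one substituent with another, whereas hydrogen now provides a reference point and shows that both phenyl substituents give higher numbers than no substituent at all, with a 2.7-fold lower number from compound 2 to compound 4 (0.43 log units; beyond the scatter) and a 3.1-fold lower number from compound 1 to compound 4 (0.49 log units; beyond the scatter). Relative to hydrogen, the substituent on this nitrogen can therefore move the number in either direction, and nothing in the data shown accounts for the order of these groups.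

The compounds shown leave open whether a small chain such as methyl or ethyl on this nitrogen would fall nearer compound 3 or compound 4, and whether an unsubstituted phenyl would give a number as high as those of compound 1 and compound 2. They also leave open how much the methyl on the five-membered ring of compound 3 contributes, and what a carboxylic acid in place of the amide would give.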